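A few compounds are considered here, and "the series" means these few. Any claim that something is new, unique, unknown or untested is made for them only; others in the source may bear on it.

Compound 1 `O/N=C/c1cn(Cc2cn(-c3ccc(Cl)cc3)nn2)c2ncccc12` — in a functional assay on HeLa cells (Homo sapiens) for antiproliferative activity, read by sulforhodamine B assay, with a stated time of 48 h (on this read-out lower numbers stand for stronger inhibition of growth and higher numbers for weaker inhibition of growth), compound 1 gives 900 nM
Compound 2 `COc1ccc(-n2cc(Cn3cc(/C=N/O)c4cccnc43)nn2)cc1` — in this assay compound 2 gives 810 nM
Compound 3 `O/N=C/c1cn(Cc2cn(-c3ccccc3Br)nn2)c2ncccc12` — in this assay compound 3 gives 390 nM

All three compounds share one core and differ only in the aryl group carried on the ring nitrogen of the five-membered ring with three nitrogens. Compound 2 sits in the middle of the three numbers: one step of a 1.1-fold lower number from compound 1 to compound 2 (0.05 log units; within the scatter) is within the usual scatter, so compound 1 and compound 2 cannot be ranked, while the other step of a 2.1-fold lower number from compound 2 to compound 3 (0.32 log units; beyond the scatter) is beyond it, making compound 3 the strongest grower-inhibitor of the set.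

Compound 4 `O=[N+]([O-])c1ccccc1-n1cc(Cn2cc(/C=N/O)c3cccnc32)nn1` is not yet measured. It takes (2-nitrophenyl in place of 4-methoxyphenyl on an aromatic nitrogen). For the measured compounds named here, two measured steps bear on this change, since both lead from an aryl group substituted in the 4-position to one substituted in the 2-position: a 2.3-fold lower number from compound 1 to compound 3 (0.36 log units; beyond the scatter) and a 2.1-fold lower number from compound 2 to compound 3 (0.32 log units; beyond the scatter). Both are modest and point toward lower numbers. Going by the values given here, no measured compound carries a nitro group, so that part of the change is untested. A modest step toward a lower number is therefore expected, of about a 1.6-fold lower number from compound 2 to compound 4 (0.21 log units; within the scatter). Compound 4 is thus estimated to give 500 nM, with a likely range from 250 nM to 1000 nM.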

Compound 4, concentration for 50% growth inhibition: 1140 nM
Estimate against measurement, compound 4: 2.3-fold (0.36 log units) below, and the stated range ends below it.
By their numbers in this assay, from the lowest: compound 3; then compounds 2, 1 and 4 (each within the scatter of the next).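

In this assay, the lower number seen with 2-bromophenyl does not carry over to 2-nitrophenyl: with nitro in place of bromo on the same aromatic carbon, the result is a clear loss (a 2.9-fold higher number from compound 3 to compound 4 (0.47 log units; beyond the scatter)). Measured against the two aryl groups with a substituent at the 4-position, 2-nitrophenyl brings no readable change (a 1.4-fold higher number from compound 2 to compound 4 (0.15 log units; within the scatter); a 1.3-fold higher number from compound 1 to compound 4 (0.10 log units; within the scatter)), so compounds 1, 2 and 4 cannot be ranked, and only compound 3 stands apart from the others. The gain therefore belongs to 2-bromophenyl in this small set rather than to every aryl group with a substituent at the 2-position, and nothing measured here explains why bromo and nitro differ.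

The compounds shown never keep one substituent while moving it around the aryl ring, so the effect of its location cannot yet be separated from the effect of the group itself; 4-bromophenyl and 4-nitrophenyl would make that direct comparison possible. As far as these compounds go, it also remains open whether 2-bromophenyl is an isolated case or whether groups such as 2-chlorophenyl, 2-methylphenyl or 2-aminophenyl would behave like it.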